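Swapping chlorine for fluorine on a triazole-linked thiocarbamate

The source may hold more compounds than are shown below. What is called first, only, known or untested is meant among the compounds shown, and "the series" means these compounds.

Of the compounds shown here, three from one series have been measured in a functional assay on MCF7 cells (Homo sapiens) for inhibition, read by MTT assay, with a stated time of 72 h; on this read-out higher numbers stand for weaker inhibition and lower numbers for stronger inhibition. Compound 1, with the structure `O=C(OCc1ccccc1)N1CCN(C(=S)SCc2cn(Cc3ccc(Cl)cc3)nn2)CC1`, gives 27500 nM. Compound 2, with the structure `O=C(OCc1ccccc1)N1CCN(C(=S)SCc2cn(Cc3ccc(F)cc3)nn2)CC1`, gives 10300 nM. The two differ in a single place: fluoro in place of chloro on an aromatic carbon, and this change made a step of a 2.7-fold lower number from compound 1 to compound 2 (0.43 log units; beyond the scatter).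

Compound 3, with the structure `S=C(SCc1cn(Cc2ccccc2Cl)nn1)N1CCNCC1`, gives 38900 nM. Its core is a different one from that of compound 1, and the difference between the two cores is not broken down here.

Compound 4, with the structure `Fc1ccccc1Cn1cc(CSC(=S)N2CCNCC2)nn1`, has not yet been measured. It stands to compound 3 as compound 2 stands to compound 1: fluoro in place of chloro on an aromatic carbon. The surroundings are not identical, though. In the measured pair the exchanged atom sits para to a large group, while in the new pair it sits ortho to a large group, so this is the same kind of change rather than the same change, and it is seen only twice among the compounds shown.

Since the measured step was modest, a step of similar direction but less certain size is expected from compound 3 to compound 4, namely a 2.2-fold lower number from compound 3 to compound 4 (0.33 log units; beyond the scatter). On that basis compound 4 is estimated to give 18000 nM in this assay, with a plausible range from 7000 nM to 45000 nM.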

Compound 4, half-maximal inhibitory concentration: 33200 nM
For compound 4 the middle estimate is 1.8-fold (0.27 log units) below the measured one; low and high end bracket the measured number.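

In this assay, replacing 2-chlorophenyl with 2-fluorophenyl gives a 1.2-fold lower number from compound 3 to compound 4 (0.07 log units; within the scatter), so on this core the exchange produces no difference that the assay can distinguish from ordinary repeat-to-repeat variation. Although only the earlier step lies beyond the scatter, the two steps cannot be told apart when set side by side: the same change on two cores in this assay, a 2.7-fold lower number (0.43 log units; beyond the scatter) from compound 1 to compound 2 and a 1.2-fold lower number (0.07 log units; within the scatter) from compound 3 to compound 4, 2.3-fold (0.36 log units) apart, within the scatter of two such steps This shows that the results are compatible with the exchange behaving alike on both cores, but it does not show that the earlier step carries over, since two pairs are very few, the step on the new core is itself within the scatter, and the two pairs are the same kind of change rather than the same change, with the exchanged atom here ortho to a large group.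

The compounds shown leave open whether a difference between the steps, if one exists, would follow the core or the place of the halogen, a question that would need the same exchange at the same place on both cores. They also leave open how a group other than a halogen, such as methoxy or nitrile, would behave at this place on either core.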